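The source may hold more compounds than are shown below. What is called first, only, known or untested is meant among the compounds shown, and "the series" means these compounds.

Compound 1 `COc1cc(Oc2cc(C)cc(C)c2)cc(Nc2ccc(C#N)cc2)n1` and compound 2 `COc1cc(Oc2c(C)cc(C)cc2C)cc(Nc2ccc(C#N)cc2)n1` share one core and differ only in the ring hung on an oxygen on an aromatic ring. Compound 3 `Cc1cc(C)c(Oc2cc(Nc3ccc(C#N)cc3)[nH]c(=O)c2Br)c(C)c1` has a different core, and compound 4 `Cc1cc(C)cc(Oc2cc(Nc3ccc(C#N)cc3)[nH]c(=O)c2Br)c1` is its still unmeasured partner. In an ADME assay on MT4 cells (Homo sapiens) for cytotoxicity, read by MTT assay, with a stated time of 5 days (a higher number here means that more compound is tolerated, a lower number that less compound is tolerated), compound 2 gives 29000 nM. In this assay compound 1 gives 20000 nM. The change that turns compound 2 into compound 1 is 3,5-dimethylphenyl in place of 2,4,6-trimethylphenyl on an oxygen on an aromatic ring and it made a 1.5-fold lower number from compound 2 to compound 1 (0.16 log units; within the scatter). For compound 3 the this assay reports only a limit of the measurement, > 294000 nM, not a number. The difference between the core of compound 2 and the core of compound 3 is not broken down here. The change from compound 3 to compound 4 is 3,5-dimethylphenyl in place of 2,4,6-trimethylphenyl on an oxygen on an aromatic ring, the same change as from compound 2 to compound 1, made at a place described in the same words. Since the earlier step stayed within the scatter, the expectation is that compound 4 will sit about where compound 3 sits, and because compound 3 stands at the limit of > 294000 nM in this assay, at which 1 of the 3 values shown sits, there is a fair chance that compound 4 also returns only a limit. Compound 4 is therefore estimated to give 250000 nM in this assay, with a likely range from 100000 nM to 400000 nM. That estimate means an expected step of an at least 1.1-fold lower number from compound 3 to compound 4 (0.07 log units; that floor lies within the scatter), resting on a 1.5-fold lower number from compound 2 to compound 1 (0.16 log units; within the scatter) seen with the same change.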

Compound 4, half-maximal cytotoxic concentration: 19000 nM
Beside the measured number, compound 4's estimate is 13-fold (1.12 log units) above it; measured number outside the range, below it.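

Testing one change on two cores shows whether its effect carries over. In this assay, putting 3,5-dimethylphenyl in place of 2,4,6-trimethylphenyl gave an at least 15-fold lower number from compound 3 to compound 4 (1.18 log units; beyond the scatter), so in this series the size of the change did not carry over from one core to the other: the same change on two cores in this assay, a 1.5-fold lower number (0.16 log units; within the scatter) from compound 2 to compound 1 and an at least 15-fold lower number (1.18 log units; beyond the scatter) from compound 3 to compound 4, at least 10-fold (1.02 log units) apart, beyond the scatter of two such steps The reading for compound 3, > 294000 nM, is a limit and not a number. These two pairs show that the same swap of rings can give very different steps on different cores, but they do not show which part of the core makes the difference, or whether either step would be repeated on a third core.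

The compounds shown leave open how other rings on the oxygen would behave on these two cores, for example a phenyl ring carrying chlorine atoms or ethyl groups in place of the methyl groups. They also leave open whether the large step belongs to this pair of rings alone or would appear with such other rings too, and whether it would be seen in cells other than those used here.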